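A few compounds are considered here, and "the series" means these few. Any claim that something is new, unique, unknown or untested is made for them only; others in the source may bear on it.

In a functional assay (aorta) with Rattus norvegicus as the target (a lower number here means that less compound is needed, a higher number that more compound is needed for the effect), three amides sharing one core have been measured:

compound 1 `O=C(Nc1cc2cc[nH]c(=O)c2cc1Cl)[C@H]1CCCN1`: 1120 nM
compound 2 `CC(C)[C@H](N)C(=O)Nc1cc2cc[nH]c(=O)c2cc1Cl`: 500 nM
compound 3 `CN1CCC(C(=O)Nc2cc3cc[nH]c(=O)c3cc2Cl)CC1`: 250 nM

Compound 3 has the lowest of these three numbers, but its gap is beyond the scatter only against compound 1, as seen in a 4.5-fold lower number from compound 1 to compound 3 (0.65 log units; beyond the scatter). Against compound 2 the gap is within the scatter, as seen in a 2.0-fold lower number from compound 2 to compound 3 (0.30 log units; within the scatter), so those two cannot be ranked.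

The unmeasured compound 4 `N[C@H]1CC[C@@H](C(=O)Nc2cc3cc[nH]c(=O)c3cc2Cl)CC1` keeps the shared core and changes the group on the carbonyl carbon: 4-aminocyclohexyl in place of 1-methylpiperidin-4-yl on a carbonyl carbon. For the measured compounds named here, no measured step makes this exact exchange, so the evidence is indirect. All three measured steps change the group at this same place. Besides the step to compound 3, the only other step beyond the scatter is a 2.2-fold lower number from compound 1 to compound 2 (0.35 log units; beyond the scatter), and both of these are modest. As far as these compounds go, with so few compounds, the direction of any shift in this assay remains open, and no step beyond the scatter is expected. For compound 4 the expected value is 300 nM, with an estimated range from 90 nM to 1000 nM. This estimate corresponds to an expected 1.2-fold higher number from compound 3 to compound 4 (0.08 log units; within the scatter).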

Compound 4, half-maximal effective concentration: 180 nM
Beside the measured number, compound 4's estimate is 1.7-fold (0.22 log units) above it; measured number inside the range.
By their numbers in this assay, from the lowest: compounds 4, 3 and 2 (each within the scatter of the next, the first and the last beyond it); then compound 1.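

At the carbonyl carbon, 4-aminocyclohexyl replaces the single hetero atom ring of 1-methylpiperidin-4-yl with a ring of carbon only and brings one hydrogen-bond donor where there was none, yet in this assay this exchange cannot be told apart from no change (a 1.4-fold lower number from compound 3 to compound 4 (0.14 log units; within the scatter)). Compound 4 nevertheless separates from the open-chain 1-amino-2-methylpropyl group (a 2.8-fold lower number from compound 2 to compound 4 (0.44 log units; beyond the scatter)), a separation that compound 3 did not achieve, and the gap to the pyrrolidin-2-yl group is the widest step in this small set (a 6.2-fold lower number from compound 1 to compound 4 (0.79 log units; beyond the scatter)), although both steps remain modest. The three six-membered or open-chain exchanges thus show that this place tolerates a ring of carbon only carrying an amine as well as a ring holding its nitrogen, but nothing available accounts for these differences.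

It remains open whether the amine on the ring matters at all, since neither an unsubstituted cyclohexyl group nor a 4-hydroxycyclohexyl group appears among the compounds shown. The other arrangement of the two defined stereocentres in 4-aminocyclohexyl is also absent, so the part played by that arrangement cannot be judged.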